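The source may hold more compounds than are shown below. What is called first, only, known or untested is meant among the compounds shown, and "the series" means these compounds.

Measured so far:
- compound 1 `Fc1cccc(N2CCN(CCCOc3ccc4c(c3)CCC4)CC2)c1`: 42%
- compound 2 `Clc1ccc(N2CCN(CCCCOc3ccc4c(c3)CCC4)CC2)cc1`: 33%

In a functional assay on the whole organism for inhibition, with Mus musculus as the target, at a dose of 25 mg/kg by the oral route (on this read-out higher numbers stand for more inhibition at the one dose given (going by the name of the read-out) and lower numbers for less inhibition), compound 1 gives 42% and compound 2 gives 33%. Of the two numbers shown, that of compound 1 is the larger, but the gap to compound 2 lies within the scatter of repeated measurements, so the two compounds cannot be told apart on these data. Among the measured compounds shown here, no pair of measured compounds differs in one place, so no measured step exists to lean on.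

The next compound, compound 3 `O=[N+]([O-])c1ccccc1N1CCN(CCCOc2ccc3c(c2)CCC3)CC1`, is to be tested in this assay. It differs from compound 1 as follows: 2-nitrophenyl in place of 3-fluorophenyl on an amine nitrogen in a ring. Nothing measured bears on this change. With only the two numbers above as a guide, no step beyond the scatter is expected in either direction; the read-out of compound 3 is expected to lie in the same band as that of compound 1 and compound 2.

Compound 3 is thus estimated at 35%, with a range from 12% to 60%, which means an expected step of a number 7 percentage points lower from compound 1 to compound 3 (within the scatter).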

Compound 3, a percentage reported as inhibition, in the whole organism at one dose (the size of the read-out at that dose, not a potency): 43%
Beside the measured number, compound 3's estimate is 8 percentage points below it; the measured number falls inside the stated range.
By their numbers in this assay, from the lowest: compounds 2, 1 and 3 (each within the scatter of the next).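

In this assay the first step readable at this place, 2-nitrophenyl in place of 3-fluorophenyl on an amine nitrogen in a ring, comes out as a number 1 percentage points higher from compound 1 to compound 3 (within the scatter) and so gives no separation between the two compounds. The exchange is not a small one on paper, with 9 heavy atoms entering for 7 and 2 hydrogen-bond acceptors entering for 0, yet at the one oral dose this read-out does not tell the two groups apart, so this place on the core of compound 1 accepts at least these two aryl groups without a visible difference. No measurement of any property of these groups stands beside the result, and the step remains a bare observation.

The step changes the group on the phenyl ring and its place on that ring together, so a 3-nitrophenyl or a 2-fluorophenyl group, or a phenyl ring carrying an amino group, would be needed to take those two changes apart. Compound 2 differs from compound 1 in more than one place, so the effect of its longer chain cannot be read, and with a single dose the read-out says nothing on potency.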